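Ester to amide at the urea terminus of compound 2

The compounds below may be only part of what the source reports. "The series", "measured", "known", "first", "only" and "open" are said of these compounds alone.

Compound 2 `Cc1cc(C(=O)N2CCCCc3ccccc32)ccc1CNC(=O)NCC(=O)OC(C)(C)C` stands at the higher end of the two numbers at hand. In a functional assay on HEK293 cells for agonist activity at Vasopressin V2 receptor (Homo sapiens), read by a luciferase reporter and cAMP accumulation (on this read-out lower numbers stand for an effect already at smaller amounts and higher numbers for an effect only at larger amounts of compound), compound 2 gives 120 nM, the highest of the pair. Its nearest neighbour is compound 1 `Cc1cc(C(=O)N2CCCCc3ccccc32)ccc1CNC(=O)Nc1ccccc1F`, which in this assay gives 30 nM. Going by the values given here, the only measured step, a 4.0-fold higher number from compound 1 to compound 2 (0.60 log units; beyond the scatter), was brought about by (tert-butoxycarbonyl)methyl in place of 2-fluorophenyl on an amide-type nitrogen.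

Compound 3 `Cc1cc(C(=O)N2CCCCc3ccccc32)ccc1CNC(=O)NCC(=O)N1CCCC1` is the next compound, not yet measured. It differs from compound 2 by pyrrolidin-1-yl in place of tert-butoxy on a carbonyl carbon. Among the compounds with values here, the single measured step concerns the exchange of a whole substituent on the urea nitrogen rather than the replacement of an ester oxygen substituent by a cyclic amine, so it offers only rough guidance. The change keeps the same number of heavy atoms at the carbonyl carbon and the rest of the molecule is unchanged. The expected outcome for compound 3 is therefore a step of no more than the usual scatter, a 1.2-fold lower number from compound 2 to compound 3 (0.08 log units; within the scatter). Compound 3 is estimated at 100 nM, with a range from 30 nM to 400 nM.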

Compound 3, half-maximal effective concentration: 100 nM
For compound 3 middle estimate and measured number coincide at the digits printed; the measured number falls inside the stated range.
By their numbers in this assay, from the lowest: compound 1; then compounds 3 and 2 (each within the scatter of the next).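

In this assay, the step of a 1.2-fold lower number from compound 2 to compound 3 (0.08 log units; within the scatter) shows that, on this carbonyl carbon, pyrrolidin-1-yl and tert-butoxy give numbers that cannot be told apart, so an oxygen-linked group is not required here for a number of this size, and a five-membered ring with a nitrogen serves as well. The step of a 3.3-fold higher number from compound 1 to compound 3 (0.52 log units; beyond the scatter) lies beyond the scatter, so compound 1, with its 2-fluorophenyl on the amide-type nitrogen, now holds the lowest number against two different ((carbonyl)methyl) substituents rather than one. Nothing available explains either step.

The compounds shown leave open how far this tolerance at the carbonyl carbon extends, since only two groups of equal heavy-atom count have been compared there, and a carboxylic acid, a primary amide, dimethylamino or piperidin-1-yl could each behave differently. They also leave open whether a longer chain between the urea nitrogen and the carbonyl would bring the number closer to that of compound 1.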